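The compounds below may be only part of what the source reports. "The series", "measured", "known", "first", "only" and "open" are said of these compounds alone.

Working notes on the series. The shared core is that of compound 1 `CC(C)=CCC[C@]1(C)/C=C/[C@@H](OC(=O)C=C(C)C)[C@](C)(O)/C=C/C(=O)/C(C(=O)O)=C\C1`, which carries a carboxy group; in a functional assay on A549 cells (Homo sapiens) for antiproliferative activity, read by MTT assay, with a stated time of 48 h (a lower number here means a stronger inhibitor, a higher number a weaker inhibitor), compound 1 gives > 10000 nM, a limit of the assay. Compound 2 `CC(C)=CCC[C@]1(C)/C=C/[C@@H](OC(=O)C=C(C)C)[C@](C)(O)CCC(=O)/C(CO)=C\C1` in this assay gives > 40000 nM, again a limit. Compound 3 `CCN(CC)C(=O)/C1=C/C[C@](C)(CCC=C(C)C)/C=C/[C@@H](OC(=O)C=C(C)C)[C@](C)(O)/C=C/C1=O`, with diethylamino in place of hydroxy on the carbonyl carbon, gives 11300 nM in this assay. The step that the limit leaves unreadable from compound 1 to compound 3 cannot be sized, since the limit of > 10000 nM in this assay, at which 1 of the 3 values shown sits, holds one end of it. Compound 4 `CC(C)=CCC[C@]1(C)/C=C/[C@@H](OC(=O)C=C(C)C)[C@](C)(O)/C=C/C(=O)/C(C(=O)N(C(C)C)C(C)C)=C\C1` differs from compound 1 by diisopropylamino in place of hydroxy on a carbonyl carbon. Within the data shown here, only the step from compound 1 to compound 3 bears on this change, and it is unreadable; the two values show no more than that the diethylamino compound gives a number while the carboxy compound sits at a limit. No step beyond the scatter is therefore expected for compound 4 in this assay, only a value of the same order as that of compound 3. Compound 4 is expected at 12000 nM, between 4000 nM and 40000 nM. The expected step that the limit leaves unreadable from compound 1 to compound 4 may again end at the limit.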

Compound 4, half-maximal inhibitory concentration: 13500 nM
Estimate against measurement, compound 4: 1.1-fold (0.05 log units) below; measured number inside the range.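

At this carbonyl carbon, diisopropylamino can now be set directly against diethylamino: in this assay there is a 1.2-fold higher number from compound 3 to compound 4 (0.08 log units; within the scatter), so these two amides do not separate. Compound 4 thus gives a second readable value for an amide at this place, which compound 3 alone could not show. The steps from compound 1 to either amide cannot be read, since compound 1 stands at a limit of the assay: the limit of > 10000 nM in this assay, at which 1 of the 4 values shown sits.

As far as these compounds go, whether either amide truly differs from the carboxy compound stays open, as does the outcome for a methyl ester, a primary amide or a piperidine amide on the same carbonyl carbon. Compound 2 differs from compound 1 in more than one place and so gives no reading on this change.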